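Swapping Thiophene for Pyridine on a Shared Triazole Core

The source may report more compounds than this note shows. Statements on the series, on what has been measured and on what is new or still open speak of the compounds shown alone.

Of the compounds shown here, three have been measured so far: compound 1 `O=C(Cn1cc(-c2ccncc2)nn1)Nc1nccs1`, compound 2 `O=C(Cn1cc(-c2cccs2)nn1)Nc1nc2ccccc2s1` and compound 3 `O=C(Cn1cc(-c2cccs2)nn1)Nc1nccs1`. In a functional assay on BMDM cells (Mus musculus, strain C57BL/6) for inhibition, with a stated time of 2 days (on this read-out higher numbers stand for weaker inhibition and lower numbers for stronger inhibition), compound 1 gives 2 nM. Compound 2 gives 21400 nM in this assay. For compound 3 this assay reports only a limit, > 30000 nM. Compound 3 and compound 1 differ in one place, (pyridin-4-yl in place of thiophen-2-yl on an aromatic carbon), and this single change produced an at least 15000-fold lower number from compound 3 to compound 1 (4.17 log units; beyond the scatter). Compound 2 stands far above compound 1 in number; how the core of compound 2 differs from the core of compound 3 is not broken down here. Compound 4 `O=C(Cn1cc(-c2ccncc2)nn1)Nc1nc2ccccc2s1` is not yet measured and arises from compound 2 through (pyridin-4-yl in place of thiophen-2-yl on an aromatic carbon). This is the same kind of change as from compound 3 to compound 1, though the surroundings differ: in compound 2 the ring atom two ring bonds away bears a large group, in compound 3 a group of 9 heavy atoms. The step from compound 2 to compound 4 is expected to be a 2100-fold lower number from compound 2 to compound 4 (3.33 log units; beyond the scatter). That expectation rests on compound 3 and compound 1, whose change gave an at least 15000-fold lower number from compound 3 to compound 1 (4.17 log units; beyond the scatter). Compound 4 is therefore estimated at 10 nM, likely between 1 nM and 300 nM.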

Compound 4, half-maximal inhibitory concentration: 50 nM
Estimate against measurement, compound 4: 5.0-fold (0.70 log units) below, and the stated range covers the measured number.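

In this assay, the change from thiophen-2-yl to pyridin-4-yl also works on the second core, where it gives a 430-fold lower number from compound 2 to compound 4 (2.63 log units; beyond the scatter), so the direction of the step is the same on both cores shown. The size of the step does not carry over, and a large effect on one core predicts only a large effect of uncertain size on the other: the same change on two cores in this assay, an at least 15000-fold lower number (4.17 log units; beyond the scatter) from compound 3 to compound 1 and a 430-fold lower number (2.63 log units; beyond the scatter) from compound 2 to compound 4, at least 35-fold (1.54 log units) apart, beyond the scatter of two such steps. What this does not show is the exact size of the earlier step or of the gap between the two steps, since compound 3 has only a limit and not a number: the limit of > 30000 nM in this assay, at which 1 of the 4 values shown sits.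

The compounds shown leave open whether a phenyl ring or a pyridin-3-yl group in place of pyridin-4-yl would also give such low numbers. They also leave open how the same change would behave on a third core, for example one carrying a carboxylic acid or an amine.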